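A few compounds are considered here, and "the series" means these few. Any claim that something is new, unique, unknown or untested is made for them only; others in the source may bear on it.

Compound 2 `Oc1cccc(-c2cc(-c3ccsc3)cc(-c3cccc(O)c3)n2)c1` is one of two compounds that have been tested in a functional assay on HCT-15 cells (Homo sapiens) for cytotoxicity, read by CCK-8 assay; on this read-out higher numbers stand for weaker inhibition and lower numbers for stronger inhibition. In this assay, going by the values given here, compound 2 gives 1630 nM, the only plain number among the two values shown. Compound 1 `Oc1cccc(-c2cc(-c3ccsc3)cc(-c3ccccc3O)n2)c1` reaches only a limit of the assay, > 50000 nM, so that (the limit of > 50000 nM in this assay, at which 1 of the 2 values shown sits). The two compounds share a core that carries a thiophen-3-yl group and two hydroxyphenyl groups, and they differ only in where the hydroxyl sits on one of those rings. Among the compounds with values here, the single measured step, an at least 30-fold lower number from compound 1 to compound 2 (1.48 log units; beyond the scatter), shows that shifting this hydroxyl can change the number a great deal.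

Compound 3 `Oc1ccc(-c2cc(-c3ccsc3)cc(-c3cccc(O)c3)n2)cc1` has not yet been measured. It differs from compound 2 in the same kind of way: 4-hydroxyphenyl in place of 3-hydroxyphenyl on an aromatic carbon. The earlier step bears on this change because an at least 30-fold lower number from compound 1 to compound 2 (1.48 log units; beyond the scatter) also moved the hydroxyl on this very ring. Going by these compounds, one step cannot tell the direction of a second shift, so a change beyond the scatter is expected, but whether upward or downward stays open. For compound 3 the expected value is 2500 nM, within the range 500 nM to 15000 nM. As a step this estimate means a 1.5-fold higher number from compound 2 to compound 3 (0.19 log units; within the scatter).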

Compound 3, half-maximal inhibitory concentration: 1180 nM
The estimate for compound 3 lay 2.1-fold (0.33 log units) above the measured number; measured number inside the range.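

In this assay, exchanging the 3-hydroxyphenyl group for the 4-hydroxyphenyl group gives a 1.4-fold lower number from compound 2 to compound 3 (0.14 log units; within the scatter), so these two placements of the hydroxyl cannot be told apart here. The 2-hydroxyphenyl group is different: the change to the 4-hydroxyphenyl group gives an at least 42-fold lower number from compound 1 to compound 3 (1.62 log units; beyond the scatter), a large step much like the earlier one, so among these three compounds only compound 1 stands apart, while compound 2 and compound 3 sit together on the side of stronger inhibition. Compound 1 supplies only a limit of the assay and not a plain number, so the true size of both large steps remains unknown: the limit of > 50000 nM in this assay, at which 1 of the 3 values shown sits.

The compounds shown leave open whether the hydroxyl itself matters at this position, a question that a plain phenyl or a methoxyphenyl group there could answer, and whether an amine or a carboxylic acid on the ring would keep the number near those of compound 2 and compound 3. They also leave open whether moving the hydroxyl on the other hydroxyphenyl ring would follow the same pattern.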